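Octylphenoxy ketone tetrazoles: from benzyl to carboxyphenyl

The source may report more compounds than this note shows. Statements on the series, on what has been measured and on what is new or still open speak of the compounds shown alone.

Compound 1 `CCCCCCCCc1ccc(OCC(=O)Cn2nnnc2C)cc1` carries a methyl on the tetrazole ring and gives 41 nM in an assay on microsomes from brain for inhibition of Fatty-acid amide hydrolase 1 (Rattus norvegicus), read by fluorescence and HPLC, with a stated time of 60 min; on this read-out higher numbers stand for weaker inhibition and lower numbers for stronger inhibition. Compound 2 `CCCCCCCCc1ccc(OCC(=O)Cn2nnnc2Cc2ccccc2)cc1` bears a benzyl at the same position and gives 320 nM in this assay. The step of a 7.8-fold higher number from compound 1 to compound 2 (0.89 log units; beyond the scatter) is the only one in the set, so compound 2 holds the highest number among the two measured compounds, and its nearest neighbour is compound 1.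

Compound 3 `CCCCCCCCc1ccc(OCC(=O)Cn2nnnc2-c2cccc(C(=O)O)c2)cc1` differs from compound 2 as follows: 3-carboxyphenyl in place of benzyl on an aromatic carbon. For the measured compounds named here, no measured step covers this exact change; the one known step, a 7.8-fold higher number from compound 1 to compound 2 (0.89 log units; beyond the scatter), shows only that enlarging the group on this ring carbon from hydrogen to phenyl raised the number. Replacing the benzyl by a ring bound directly, now carrying a carboxylic acid, is a different kind of move, so the guide is weak. The expectation for compound 3 is nevertheless a further modest rise, a 2.2-fold higher number from compound 2 to compound 3 (0.34 log units; beyond the scatter), in this assay. Compound 3 is accordingly estimated at 700 nM, with a range from 150 nM to 3500 nM.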

Compound 3, half-maximal inhibitory concentration: 1800 nM
For compound 3 the middle estimate is 2.6-fold (0.41 log units) below the measured one, within the range that was stated.
By their numbers in this assay, from the lowest: compound 1; then compound 2; then compound 3.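

The aromatic carbon between two ring nitrogen atoms tolerates 3-carboxyphenyl, but at a further cost: in this assay, replacing benzyl gives a 5.6-fold higher number from compound 2 to compound 3 (0.75 log units; beyond the scatter), and replacing methyl gives a 44-fold higher number from compound 1 to compound 3 (1.64 log units; beyond the scatter), which is the largest step in the set and makes compound 3 the weakest of the three inhibitors. Across these three compounds, the number rises in the order methyl, benzyl, 3-carboxyphenyl, and none of them goes against that order, although three compounds do not establish a trend. The change from benzyl to 3-carboxyphenyl moves the ring directly onto the aromatic carbon and introduces a carboxylic acid in one step, so these two changes cannot be separated here, and no measurement available bears on the cause of the rise.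

A phenyl without the carboxylic acid and a benzyl bearing a carboxylic acid would divide the step between those two changes. Also open, going by these compounds, is whether a methyl ester or an amide in place of the carboxylic acid would give a lower or a higher number at this position.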